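A few compounds are considered here, and "the series" means these few. Any claim that something is new, unique, unknown or untested is made for them only; others in the source may bear on it.

Working notes on the series.

Compound 1 `CC[C@@H]1C(=O)N(C)c2cnc(Nc3ccc(S(=O)(=O)NC)cc3)nc2N1C1CCCC1` and compound 2 `CCCNS(=O)(=O)c1ccc(Nc2ncc3c(n2)N(C2CCCC2)[C@H](CC)C(=O)N3C)cc1` share a core and differ in one place: hydrogen in place of ethyl on a saturated chain carbon bound to a sulfonamide nitrogen. In a functional assay on A549 cells (Homo sapiens) for antiproliferative activity, read by CCK-8 assay, with a stated time of 72 h (on this read-out lower numbers stand for stronger inhibition of growth and higher numbers for weaker inhibition of growth), compound 1 gives 183 nM, and compound 2 gives 563 nM. Among the compounds with values here, the step of a 3.1-fold lower number from compound 2 to compound 1 (0.49 log units; beyond the scatter) is the only measured step of its kind here.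

Compound 3 `CCCCNC(=O)c1ccc2c(ccn2-c2ncc3c(n2)N(c2ccn(C)n2)C(CC)C(=O)N3C)c1` carries a different core; the difference between the core of compound 3 and the core of compound 2 is not broken down here. In this assay compound 3 gives 37300 nM, the highest number of the three measured compounds and well apart from both compound 1 and compound 2.

Compound 4 `CCNC(=O)c1ccc2c(ccn2-c2ncc3c(n2)N(c2ccn(C)n2)C(CC)C(=O)N3C)c1` is not yet measured. It differs from compound 3 by hydrogen in place of ethyl on a saturated chain carbon, two bonds along the chain from an amide-type nitrogen. Within the data shown here, this is the same kind of change as the one from compound 2 to compound 1, but not the same: there the place was on a saturated chain carbon bound to a sulfonamide nitrogen, here it is on a saturated chain carbon, two bonds along the chain from an amide-type nitrogen, and the surrounding core is different as well. The expected step from compound 3 to compound 4 in this assay is a 1.7-fold lower number from compound 3 to compound 4 (0.23 log units; within the scatter), smaller than a 3.1-fold lower number from compound 2 to compound 1 (0.49 log units; beyond the scatter) and held close to the scatter, because the earlier step of a 3.1-fold lower number from compound 2 to compound 1 (0.49 log units; beyond the scatter) sits at another place on another core and gives only a loose guide. Compound 4 is therefore estimated at 22000 nM, with a likely range from 8000 nM to 60000 nM.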

Compound 4, concentration for 50% growth inhibition: 21700 nM
Compound 4: the middle estimate sits 1.0-fold (0.01 log units) above what was measured; the measured number falls inside the stated range.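

In this assay, replacing butyl with ethyl on the amide-type nitrogen gives a 1.7-fold lower number from compound 3 to compound 4 (0.24 log units; within the scatter), so this pair cannot be told apart on this read-out. Set beside the earlier step on the core of compound 1, the new step does not differ measurably from it, and the change behaves compatibly on both cores: the same change on two cores in this assay, a 3.1-fold lower number (0.49 log units; beyond the scatter) from compound 2 to compound 1 and a 1.7-fold lower number (0.24 log units; within the scatter) from compound 3 to compound 4, 1.8-fold (0.25 log units) apart, within the scatter of two such steps. Within the data shown here, this agreement does not show that the change carries over with a fixed size, since it rests on only two steps, only one of them lies beyond the scatter, and they sit at different places, one on a chain bound to a sulfonamide nitrogen and the other on a chain at an amide-type nitrogen, as well as on different cores.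

The compounds shown leave open how the read-out responds at these places to a longer chain such as hexyl, or to a chain carrying an amine or a carboxylic acid. They also leave open whether the step seen with the sulfonamide would stay beyond the scatter on the core of compound 3, or whether the amide-type chain would give a larger step on the core of compound 1.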